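The source may report more compounds than this note shows. Statements on the series, on what has been measured and on what is new or still open speak of the compounds shown alone.

Among the measured compounds shown here, in an ADME assay on A549 cells (Homo sapiens) for cytotoxicity, read by resazurin assay, with a stated time of 48 h (on this read-out higher numbers stand for lower toxicity in this test and lower numbers for higher toxicity in this test), two compounds on a shared core have numbers so far. Compound 1 `O=C(Nc1ccc(NCc2ccc(C(F)(F)F)cc2)cc1Cl)c1cc(Cl)ccc1O` gives 62700 nM in this test, and compound 2 `O=C(Nc1ccc(NCCCO)cc1Cl)c1cc(Cl)ccc1O` gives 106000 nM in this test. These two values lie within the scatter of each other, so compound 2 cannot be set apart from compound 1.

The next structure is compound 3 `CC(C)(C)OC(=O)NCCNc1ccc(NC(=O)c2cc(Cl)ccc2O)c(Cl)c1`, and its difference from compound 2 is (tert-butoxycarbonyl)amino in place of hydroxymethyl on a saturated chain carbon, two bonds along the chain from a nitrogen on an aromatic ring in this one place. In words, (tert-butoxycarbonyl)amino stands in place of hydroxymethyl on a saturated chain carbon, two bonds along the chain from a nitrogen on an aromatic ring.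

For the measured compounds named here, only one measured step bears on this chain, namely a 1.7-fold higher number from compound 1 to compound 2 (0.23 log units; within the scatter) for the exchange of 4-(trifluoromethyl)phenyl and 2-hydroxyethyl. With that single step as a guide, no change beyond the scatter is expected in this assay for the new group. The estimate corresponds to a 1.4-fold lower number from compound 2 to compound 3 (0.15 log units; within the scatter) and is expected to stay within the scatter. Compound 3 is estimated at 75000 nM with an expected range of 30000 nM to 170000 nM in this test.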

Compound 3, half-maximal cytotoxic concentration: 25000 nM
The estimate for compound 3 lay 3.0-fold (0.48 log units) above the measured number; the whole stated range lies above it.
By their numbers in this assay, from the lowest: compound 3; then compounds 1 and 2 (each within the scatter of the next).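

In this assay, among the compounds shown here, this position on the chain proves sensitive to the group it carries: (tert-butoxycarbonyl)amino in place of hydroxymethyl gives a 4.2-fold lower number from compound 2 to compound 3 (0.63 log units; beyond the scatter) and is the first change here to pass beyond the scatter. The comparison with the aryl-bearing compound points the same way, with ((tert-butoxycarbonyl)amino)methyl in place of 4-(trifluoromethyl)phenyl giving a 2.5-fold lower number from compound 1 to compound 3 (0.40 log units; beyond the scatter), so compound 3 stands apart from both other compounds as the most toxic of the three in this test, although both steps are modest in size. Compounds 1 and 2 had shown only that two very different groups at this place could not be told apart, whereas this result shows that the group at this place can shift the number, and no available measurement accounts for that shift.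

The compounds shown leave open whether the lower number belongs to the whole (tert-butoxycarbonyl)amino group or to only part of it, a question that a free primary amine or a simple acetamide on the same chain would address. They also leave open how a carboxylic acid or a longer chain carrying the same group would read in this assay.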